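The source may hold more compounds than are shown below. What is called first, only, known or untested is meant among the compounds shown, and "the series" means these compounds.

Compound 1, `COc1ccc(N(C)c2nc(C)nc3ccccc23)cc1C(=O)OCCC[Se]C#N`, is the weakest of the three compounds measured here in a functional assay on MDA-MB-231 cells (Homo sapiens) for inhibition, read by MTT assay, with a stated time of 48 h; a higher number here means a weaker inhibitor, a lower number a stronger inhibitor: compound 1 gives 1180 nM, while compound 2, `Cc1nc(N(C)c2ccc([Se]C#N)c(Cl)c2)c2ccccc2n1`, gives 9 nM and compound 3, `Cc1nc(N(C)c2ccc([Se]C#N)c(F)c2)c2ccccc2n1`, gives 6 nM. Both of those numbers lie far lower than that of compound 1, beyond the scatter. For the measured compounds named here, the one step recorded between measured compounds, a 1.5-fold lower number from compound 2 to compound 3 (0.18 log units; within the scatter), concerns a halogen swap and says nothing about the side chain carried by compound 1.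

Compound 4, `COc1ccc(N(C)c2nc(C)nc3ccccc23)cc1OCCCCC[Se]C#N`, differs from compound 1 in exactly that side chain: a group of 9 heavy atoms (6 carbon, 1 nitrogen, 1 oxygen, 1 selenium; no ring) in place of a group of 9 heavy atoms (5 carbon, 1 nitrogen, 2 oxygen, 1 selenium; no ring), on an aromatic carbon. The new group sits on the aromatic carbon ortho to a methoxy group and meta to a large group, as before; the ester linkage that leaves is replaced by an ether linkage with a longer chain.

Going by the values given here, no measured pair covers a change of this kind, so there is no step from which to read a direction. In the absence of any bearing step, compound 4 is expected to stay close to compound 1, with a step of a 1.3-fold lower number from compound 1 to compound 4 (0.12 log units; within the scatter) in this assay that lies within the scatter. Compound 4 is therefore estimated at 900 nM, within a range from 250 nM to 3500 nM.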

Compound 4, half-maximal inhibitory concentration: 4410 nM
Compound 4: middle estimate off by 4.9-fold (0.69 log units), on the low side; the measured number lies above the stated range.
By their numbers in this assay, from the lowest: compounds 3 and 2 (each within the scatter of the next); then compound 1; then compound 4.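

Among the earlier compounds the only recorded step was a halogen swap, which left the side chain untouched; this pair gives the first reading on the group at the aromatic carbon ortho to a methoxy group and meta to a large group, with a 3.7-fold higher number from compound 1 to compound 4 (0.57 log units; beyond the scatter) in this assay. The position is therefore not silent in this assay: two groups of the same size, 9 heavy atoms each and neither with a ring, give numbers that stand apart, although the step is a modest one. What separates them is a composition of 6 carbon and 1 oxygen in the entering group against 5 carbon and 2 oxygen in the group that leaves, with the double bond gone and 2 hydrogen-bond acceptors in place of 3, and nothing at hand accounts for the step.

The ether linkage and the longer chain enter together, so the step cannot be divided between them. As far as these compounds go, how an ester on a longer chain, an ether on a shorter chain or an amide linkage at this carbon would stand in this assay stays open.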